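Aryl exchange on the hydrazone carbon: compound 1 to compound 4

The source may hold more compounds than are shown below. What is called first, only, known or untested is meant among the compounds shown, and "the series" means these compounds.

Three compounds carry readings in a functional assay, read by spectrophotometry, with a stated time of 15 min, tested at 40 ug/mL; on this read-out lower numbers stand for a weaker effect and higher numbers for a stronger effect at the one concentration tested. Compound 1 `COC(=O)c1cc(-c2csc(N/N=C/c3cccs3)n2)ccc1OCc1ccccc1` gives 82.8%, the second highest of the three numbers. Compound 2 `Cc1ccc(-c2csc(N/N=C/c3ccc(Cl)cc3Cl)n2)cc1` gives 80.4%, and compound 3 `Fc1ccc(-c2csc(N/N=C/c3cccs3)n2)cc1` gives 87.5%; both readings lie within the scatter of compound 1, so no order among the three is claimed. Within the data shown here, no two measured compounds differ in only one place, so no measured single step exists. Compound 4 `COC(=O)c1cc(-c2csc(N/N=C/c3ccc(Cl)cc3Cl)n2)ccc1OCc1ccccc1` differs from compound 1 as 2,4-dichlorophenyl in place of thiophen-2-yl on a carbon with a double bond to nitrogen. Compound 2 already carries the 2,4-dichlorophenyl group and gives 80.4% in this assay. On that reading, no shift beyond the scatter is expected for compound 4. The step expected is a number 1.8 percentage points lower from compound 1 to compound 4 (within the scatter). Compound 4 is estimated at 81%, with a range from 68% to 91%.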

Compound 4, a percentage reported as inhibition, at one concentration (the size of the read-out at that concentration, not a potency): 63.5%
The estimate for compound 4 lay 17.5 percentage points above the measured number; the whole stated range lies above it.
By their numbers in this assay, from the lowest: compound 4; then compounds 2, 1 and 3 (each within the scatter of the next).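

In this assay, among these compounds, placing 2,4-dichlorophenyl in place of thiophen-2-yl on a carbon with a double bond to nitrogen gives a number 19.3 percentage points lower from compound 1 to compound 4 (beyond the scatter) as the first single-place step. Among the compounds shown here, the reading at this position therefore responds to the exchange of this aromatic group on the core of compound 1, which the earlier compounds, none differing in only one place, could not show.

Going by these compounds, whether a phenyl carrying one chlorine, an amine or a carboxylic acid keeps the reading of compound 1 remains open. The data shown offer no explanation for this step.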